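This account rests on a few compounds, and the source may have more. Where it says the series, first, only, none or still open, it means among the compounds named here.

Measured compounds and their values in a functional assay on cells for agonist activity at Glucose-dependent insulinotropic receptor (Homo sapiens), read by a luciferase reporter, with a stated time of 4 h; a higher number here means that more compound is needed for the effect, a lower number that less compound is needed:
- compound 1, `CS(=O)(=O)c1ccc2c(c1)CCN2c1ncnc2c(C3CCN(c4ncccn4)CC3)coc12`, gives 512 nM
- compound 2, `CC(=O)c1cnc(N2CCC(c3coc4c(N5CCc6cc(S(C)(=O)=O)ccc65)ncnc34)CC2)nc1`, gives 78 nM
- compound 3, `CS(=O)(=O)c1ccc2c(c1)CCN2c1ncnc2c(C3CCN(c4ncc(O)cn4)CC3)coc12`, gives 391 nM

Compound 3 stands second highest of the three numbers. Its nearest neighbour is compound 1, and the two values lie within the scatter of each other, as a 1.3-fold lower number from compound 1 to compound 3 (0.12 log units; within the scatter) shows. The furthest is compound 2, which needs clearly less compound: a 5.0-fold higher number from compound 2 to compound 3 (0.70 log units; beyond the scatter).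

Compound 4, `COc1cnc(N2CCC(c3coc4c(N5CCc6cc(S(C)(=O)=O)ccc65)ncnc34)CC2)nc1`, has not been measured. It differs from compound 3 by methyl in place of hydrogen on an oxygen on an aromatic ring. For the measured compounds named here, no measured step swaps a hydroxy for a methoxy, so the nearest guides are indirect. Adding a hydroxy to compound 1 changed little, while adding an acetyl gave a 6.6-fold lower number from compound 1 to compound 2 (0.82 log units; beyond the scatter), a modest gain. A methoxy is neither of these, so the direction is uncertain; a small gain or no change beyond the scatter seems the likeliest outcome.

For compound 4 the expected step is a 1.5-fold lower number from compound 3 to compound 4 (0.18 log units; within the scatter). The estimated value of compound 4 in this assay is therefore 260 nM, with a likely range from 80 nM to 800 nM.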

Compound 4, half-maximal effective concentration: 310 nM
Estimate against measurement, compound 4: 1.2-fold (0.08 log units) below, within the range that was stated.
By their numbers in this assay, from the lowest: compound 2; then compounds 4, 3 and 1 (each within the scatter of the next).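

In this assay, putting a methyl on the oxygen of the 5-hydroxypyrimidin-2-yl group, which turns it into the 5-methoxypyrimidin-2-yl group, leaves the number within the scatter (a 1.3-fold lower number from compound 3 to compound 4 (0.10 log units; within the scatter)). The methoxy compound also cannot be told apart from the compound with only hydrogen at this aromatic carbon (a 1.7-fold lower number from compound 1 to compound 4 (0.22 log units; within the scatter)), whereas methoxy in place of acetyl gives a clear step in the unfavourable direction (a 4.0-fold higher number from compound 2 to compound 4 (0.60 log units; beyond the scatter)), so among hydrogen, hydroxy, methoxy and acetyl, only acetyl stands apart at this position. Nothing measured here explains why these groups fall out this way.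

As far as these compounds go, what remains open is whether this result is particular to the acetyl group or extends to other groups at the same carbon, such as a nitrile, a methyl ester or an amide. A longer ketone such as propanoyl, or an ethoxy group in place of methoxy, would also show how much room the position allows for change in either series.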